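Chloro on the anilide ring: cytotoxicity notes

A few compounds are considered here, and "the series" means these few. Any claim that something is new, unique, unknown or untested is made for them only; others in the source may bear on it.

The three measured compounds are read in an ADME assay on HepG2 cells (Homo sapiens) for cytotoxicity, read by trypan blue exclusion, with a stated time of 48 h, in the presence of a further agent that is not named here; a lower number here means that less compound is tolerated, a higher number that more compound is tolerated. Compound 1 `c1ccc(Cn2cnc3c(-c4ccco4)nccc32)cc1` gives only a limit in this assay, > 25000 nM, and no number. Compound 3 `COc1ccc(NC(=O)COc2cc(C)nc3ccc(OC)cc23)c(OC)c1` likewise gives only a limit, > 131000 nM. For the measured compounds named here, compound 2 `COc1ccc2nc(C)cc(OCC(=O)Nc3ccccc3)c2c1` is the single compound with a number, 118000 nM in this assay, so it is the one fixed point of the set. Of the other two values, one sits at the limit of > 131000 nM in this assay, at which 1 of the 3 values shown sits. The remaining one sits at the limit of > 25000 nM in this assay, at which 1 of the 3 values shown sits.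

Compound 4 `COc1ccc2nc(C)cc(OCC(=O)Nc3ccccc3Cl)c2c1` is not yet measured. It differs from compound 2 by chloro in place of hydrogen on an aromatic carbon of the six-membered carbon ring, ortho to a large group, so that anilino becomes (2-chlorophenyl)amino. Going by the values given here, no measured step of this kind exists in the set, and a single chlorine added to the anilide is not expected to move this assay beyond its scatter in either direction. Compound 4 is therefore estimated at about 95000 nM, within 40000 nM to 220000 nM. The expected step is a 1.2-fold lower number from compound 2 to compound 4 (0.09 log units; within the scatter), inside the usual scatter.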

Compound 4, half-maximal cytotoxic concentration: > 140000 nM
Compound 4: a limit, no number; the forecaster's own chance of this, stated with the estimate: 30%; middle value at least 1.4-fold (0.16 log units) from the limit.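

Compound 4 gives a limit and not a number in this assay: the limit of > 140000 nM in this assay, at which 1 of the 4 values shown sits. For the compounds shown here, the only step in the set is an at least 1.1-fold higher number from compound 2 to compound 4 (0.07 log units; that floor lies within the scatter), and it shows that chloro in place of hydrogen on an aromatic carbon of the anilide ring, ortho to a large group, brings no lower number here. How far the number rises, if it rises at all, cannot be read from a limit.

From the compounds shown here alone, whether an amine or a carboxylic acid on that same carbon would leave the number as high in this assay stays open. Also open, going by these compounds, is how chloro would read on any other carbon of that ring or on the shared core.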